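The source may hold more compounds than are shown below. What is called first, only, known or untested is meant among the compounds shown, and "the series" means these compounds.

Measured compounds:
- compound 1 `CN1CCN(c2ccc(Nc3nc(-c4cccc(NC(=O)c5ccc(C(F)(F)F)cc5)c4)sc3C(N)=O)cc2)CC1`: in a functional assay on Ramos cells (Homo sapiens) for antiproliferative activity, read by CCK-8 assay, with a stated time of 72 h (a lower number here means a stronger inhibitor, a higher number a weaker inhibitor), compound 1 gives 1580 nM
- compound 2 `CN1CCN(c2ccc(Nc3nc(-c4cccc(NC(=O)c5ccc(C(C)(C)C)cc5)c4)sc3C(N)=O)cc2)CC1`: compound 2 gives 8600 nM
- compound 3 `CN1CCN(c2ccc(Nc3nc(-c4cccc(NC(=O)c5cccc(F)c5)c4)sc3C(N)=O)cc2)CC1`: compound 3 gives "not determined" (no result reported)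

Compound 3 therefore stands nowhere on the measured scale; only compound 1 and compound 2 provide readings. Compound 4 `CN1CCN(c2ccc(Nc3nc(-c4cccc(NC(=O)c5ccc(F)c(Cl)c5)c4)sc3C(N)=O)cc2)CC1` differs from compound 3 by 3-chloro-4-fluorophenyl in place of 3-fluorophenyl on a carbonyl carbon. Going by the values given here, the single measured step, a 5.4-fold higher number from compound 1 to compound 2 (0.74 log units; beyond the scatter), concerns a different exchange on the same outer phenyl ring and shows that swapping groups there shifts the number modestly, beyond the scatter. Among the compounds with values here, no step directly covers the exchange in hand, so the direction is uncertain. Compound 4 is expected to land near compound 1, at roughly 2500 nM, within a wide range from 600 nM to 10000 nM.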

Compound 4, half-maximal inhibitory concentration: 4830 nM
Estimate against measurement, compound 4: 1.9-fold (0.29 log units) below; low and high end bracket the measured number.
By their numbers in this assay, from the lowest: compound 1; then compounds 4 and 2 (each within the scatter of the next).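

In this assay the 3-chloro-4-fluorophenyl group on the carbonyl carbon can now be compared with two other rings: there is a 3.1-fold higher number from compound 1 to compound 4 (0.49 log units; beyond the scatter), beyond the scatter, and a 1.8-fold lower number from compound 2 to compound 4 (0.25 log units; within the scatter), within it. Among these three amides, compound 1, with 4-(trifluoromethyl)phenyl, thus keeps the lowest number, while the chlorine-and-fluorine ring of compound 4 does not separate from the 4-(tert-butyl)phenyl ring of compound 2. No measurement here explains these differences. With no reading for compound 3, the exchange of 3-fluorophenyl for 3-chloro-4-fluorophenyl itself cannot be read. Also open, from the compounds shown here alone, is how an amine or a carboxylic acid on this outer ring would behave.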